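The source may hold more compounds than are shown below. What is called first, only, known or untested is meant among the compounds shown, and "the series" means these compounds.

Compound 1 `CCOC(=O)c1[se]c(N/N=C/c2ccc(Cl)cc2)nc1C` and compound 3 `CCOC(=O)c1[se]c(N(/N=C/c2ccc(Cl)cc2)C(C)=O)nc1C` share one core, while compound 2 `CC(=O)c1[se]c(N/N=C/c2csc(-c3ccccc3)n2)nc1C` and compound 4 `CC(=O)c1[se]c(N(/N=C/c2csc(-c3ccccc3)n2)C(C)=O)nc1C` share another; how the core of compound 2 differs from the core of compound 1 is not broken down here. The three measured compounds were tested in a functional assay on HepG2 cells (Homo sapiens) for cytotoxicity, read by XTT assay, with a stated time of 72 h; a lower number here means a stronger inhibitor, a higher number a weaker inhibitor. In this assay compound 1 gives 52800 nM, compound 3 gives 55200 nM and compound 2 gives 61300 nM. These three readings lie within the usual scatter of one another, so none of them can be called weaker or stronger than the rest.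

Compound 3 differs from compound 1 by a single change, (acetyl in place of hydrogen on a nitrogen on an aromatic ring). That change produced the step of a 1.0-fold higher number from compound 1 to compound 3 (0.02 log units; within the scatter), which is to say the reading was essentially unchanged. The same change, (acetyl in place of hydrogen on a nitrogen on an aromatic ring), turns compound 2 into compound 4. The place where it is made is described in the same words for both pairs, so it is the same change carried over to a different core.

Because the step of a 1.0-fold higher number from compound 1 to compound 3 (0.02 log units; within the scatter) stayed within the scatter, the expected step here is a 1.0-fold higher number from compound 2 to compound 4 (0.01 log units; within the scatter), again within the scatter. Compound 4 is therefore estimated to give 63000 nM in this assay. Most repeated measurements of compound 4 are expected to fall between 35000 nM and 115000 nM. Among the measured compounds shown here, this expectation rests on only one earlier pair and is held loosely.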

Compound 4, half-maximal inhibitory concentration: 29400 nM
Estimate against measurement, compound 4: 2.1-fold (0.33 log units) above; the whole stated range lies above it.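

In this assay, putting acetyl in place of hydrogen on the nitrogen gave a 2.1-fold lower number from compound 2 to compound 4 (0.32 log units; beyond the scatter), a modest step that clears the scatter, whereas the same change on the core of compound 1 left the reading essentially unchanged. Set side by side, however, the two steps cannot be told apart: the same change on two cores in this assay, a 1.0-fold higher number (0.02 log units; within the scatter) from compound 1 to compound 3 and a 2.1-fold lower number (0.32 log units; beyond the scatter) from compound 2 to compound 4, 2.2-fold (0.34 log units) apart, within the scatter of two such steps. Among the compounds shown here, the result therefore does not show that the core alters what this change does, although it also does not prove that the change carries over unaltered, since each core offers only one pair, and the larger step on the core of compound 2 may be real or may be ordinary variation between measurements.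

The compounds shown have only hydrogen or acetyl on this nitrogen, so it remains open whether a methyl group, a longer acyl chain such as propanoyl, or a benzoyl group there would move the reading on either core. Also open, going by these compounds, is which part of the difference between the two cores, if any, matters for this change, and a further pair on a third core would help to settle whether the step depends on the core at all.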